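The source may hold more compounds than are shown below. What is called first, only, known or untested is meant among the compounds shown, and "the series" means these compounds.

In a functional assay on HCT-116 cells (Homo sapiens) for cytotoxicity, read by MTT assay, with a stated time of 48 h (a lower number here means a stronger inhibitor, a higher number a weaker inhibitor), compound 1 (`COc1cc(C(=O)c2cn(-c3cccc(N)c3)cc2-c2ccccc2F)cc(OC)c1OC`) gives 42 nM and compound 2 (`COc1cc(C(=O)c2cn(-c3cccc(N)c3)cc2-c2ccccc2[N+](=O)[O-])cc(OC)c1OC`) gives 44 nM with the two lying within the scatter of each other. Compound 3 (`COc1cc(C(=O)c2cn(-c3cccc(N)c3)cc2-c2ccc(N)cc2)cc(OC)c1OC`) has 4-aminophenyl in place of 2-nitrophenyl on an aromatic carbon. Among the measured compounds shown here, the one measured step in the group at this place (a 1.0-fold higher number from compound 1 to compound 2 (0.02 log units; within the scatter)) puts nitro in place of fluoro and stays within the scatter, so no step beyond the scatter is expected, although no measured compound carries 4-aminophenyl. The estimated step (a 1.3-fold higher number from compound 2 to compound 3 (0.10 log units; within the scatter)) is expected to be small. In this assay compound 3 is expected at 55 nM with 14 nM to 220 nM as the estimated range.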

Compound 3, half-maximal inhibitory concentration: 27 nM
The estimate for compound 3 lay 2.0-fold (0.31 log units) above the measured number; the measured number falls inside the stated range.
By their numbers in this assay, from the lowest: compounds 3, 1 and 2 (each within the scatter of the next).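

In this assay, 4-aminophenyl at this position gives a 1.6-fold lower number from compound 2 to compound 3 (0.21 log units; within the scatter) and a 1.6-fold lower number from compound 1 to compound 3 (0.19 log units; within the scatter). The position thus holds a group bearing its substituent at the 4-position as well as the 2-fluorophenyl and 2-nitrophenyl groups, with all three compounds remaining within the scatter of one another. No measurement bearing on this result is available to explain it.

Since this change alters both the substituent and where it sits on the phenyl ring, the two contributions remain unseparated; 2-aminophenyl or 4-nitrophenyl would separate them. Unsubstituted phenyl and a 4-carboxylic acid on the phenyl ring also remain open.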